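The compounds below may be only part of what the source reports. "The series", "measured", "known", "first", "only" and "open" are said of these compounds alone.

In a functional assay on Bel-7402 cells (Homo sapiens) for inhibition, read by MTT assay, with a stated time of 24 h, tested at 1 ug/mL (a higher number here means more inhibition of growth at the concentration tested, a lower number less inhibition of growth), compound 1 `O=C(CCCCC1CCSS1)NO` gives 7.39% and compound 2 `O=C(CCCCC1CCSS1)Nc1ccc(OC(F)(F)F)cc1` gives 0.29%. Among the measured compounds shown here, these two numbers lie within the scatter of each other, so compound 1 cannot be told apart from the only other compound measured so far. Compound 3 `O=C(CCCCC1CCSS1)Nc1ccccn1` has not yet been measured. It differs from compound 1 as follows: pyridin-2-yl in place of hydroxy on an amide-type nitrogen. In short, pyridin-2-yl stands in place of hydroxy on an amide-type nitrogen. For the measured compounds named here, no measured pair differs in just one place, so no direct step is available as a guide. Compound 2 also carries a ring on that nitrogen and gives 0.29%, so no shift beyond the scatter is expected in this assay, in either direction. The expected change is a number 2.4 percentage points lower from compound 1 to compound 3 (within the scatter). For compound 3, the estimated value is 5%, with an expected range of 0% to 15%.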

Compound 3, percent growth inhibition at one concentration: "not active" (no number reported)
Nothing numeric was reported for compound 3; no gap can be computed for the estimate.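

Among the compounds shown here, compound 3 was reported as "not active" in this assay, without a number, so no step from compound 1 to compound 3 can be read, and no evidence on the result is available. The compounds shown leave open how the group on the amide-type nitrogen affects growth inhibition in this assay.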